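Butyl ether extension in the ether series

This account rests on a few compounds, and the source may have more. Where it says the series, first, only, none or still open, it means among the compounds named here.

Values in a functional assay on KB cells (Homo sapiens) for inhibition; on this read-out lower numbers stand for stronger inhibition and higher numbers for weaker inhibition:
- compound 1 `COC[C@H]1O[C@@H](n2c(Cl)nc3cc(Cl)c(Cl)cc32)[C@H](OC(C)=O)[C@@H]1OC(C)=O` gives 80000 nM
- compound 2 `CCOC[C@H]1O[C@@H](n2c(Cl)nc3cc(Cl)c(Cl)cc32)[C@H](OC(C)=O)[C@@H]1OC(C)=O` gives 60000 nM

Within the data shown here, compound 2, at 60000 nM, cannot be separated from compound 1, the only other measured compound; the step between them is a 1.3-fold lower number from compound 1 to compound 2 (0.12 log units; within the scatter) and nothing more can be said of its rank. Compound 3 `CCCCOC[C@H]1O[C@@H](n2c(Cl)nc3cc(Cl)c(Cl)cc32)[C@H](OC(C)=O)[C@@H]1OC(C)=O` takes the ethoxy to butoxy, (ethyl in place of hydrogen on a saturated chain carbon, two bonds along the chain from an oxygen on a saturated carbon), that is, ethyl in place of hydrogen on a saturated chain carbon, two bonds along the chain from an oxygen on a saturated carbon. Among the measured compounds shown here, only one measured step bears on this, a shorter chain extension, a 1.3-fold lower number from compound 1 to compound 2 (0.12 log units; within the scatter), so no shift beyond the scatter is expected in this assay, although one small step is a thin guide for a longer extension. The expected change is a 1.3-fold lower number from compound 2 to compound 3 (0.12 log units; within the scatter) in this estimate. For compound 3 the estimated value is 45000 nM, with an expected range of 18000 nM to 110000 nM as the outcome.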

Compound 3, half-maximal inhibitory concentration: > 100000 nM
Compound 3 was reported as a limit; the forecaster's own chance of this, stated with the estimate: 15%; middle value at least 2.2-fold (0.34 log units) away from the limit.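

In this assay compound 3 stands only as a limit, > 100000 nM. Ethyl in place of hydrogen on a saturated chain carbon, two bonds along the chain from an oxygen on a saturated carbon, gives an at least 1.6-fold higher number from compound 2 to compound 3 (0.22 log units; that floor lies within the scatter), and the larger chain extension gives an at least 1.2-fold higher number from compound 1 to compound 3 (0.09 log units; that floor lies within the scatter). Both steps are floors, so the butoxy chain shows no sign of stronger inhibition than the two shorter ethers, yet no loss is established and the true size of either step stays unknown: the limit of > 100000 nM in this assay, at which 1 of the 3 values shown sits.

From the compounds shown here alone, whether an amine, a carboxylic acid or a free hydroxyl in place of the ether chain would give a clearly lower number stays open. A chain longer than butyl is open as well.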